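The source may hold more compounds than are shown below. What is called first, only, known or untested is meant among the compounds shown, and "the series" means these compounds.

Three compounds built on a shared core are compared here: compound 1 (`Cc1cccc(-c2cc(-c3ccc(Cl)o3)cc(-c3ccsc3)n2)c1`), compound 2 (`Clc1ccc(-c2cc(-c3ccc(Cl)o3)cc(-c3ccsc3)n2)cc1`) and compound 3 (`Cc1ccc(-c2cc(-c3ccc(Cl)o3)cc(-c3ccsc3)n2)cc1`). Within the data shown here, in a functional assay on HCT-15 cells (Homo sapiens) for cytotoxicity, in the presence of a further agent that is not named here (a higher number here means a weaker inhibitor, a lower number a stronger inhibitor), compound 2 gives 5190 nM as the lower of the two numbers so far, while compound 1 gives 21700 nM as the higher.

Compound 3 differs from compound 2 by one small edit, methyl in place of chloro on an aromatic carbon, para to a large group (methyl in place of chloro on an aromatic carbon). Among the measured compounds shown here, only one measured step bears on this edit (a 4.2-fold lower number from compound 1 to compound 2 (0.62 log units; beyond the scatter)), where 4-chlorophenyl stands in place of 3-methylphenyl. That step is modest but beyond the scatter. For the measured compounds named here, it changes both the group and where the group sits, so it cannot show how much comes from the group alone, and no measured pair isolates that change.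

Since compound 1 carries a methyl group and gives 21700 nM, a modest rise is expected, probably smaller than the measured step. The expected step is a 1.7-fold higher number from compound 2 to compound 3 (0.24 log units; within the scatter) by this estimate. Compound 3 is expected at about 9000 nM, with an estimated range from 3500 nM to 22000 nM in this assay.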

Compound 3, half-maximal inhibitory concentration: 7410 nM
Compound 3: the middle estimate sits 1.2-fold (0.08 log units) above what was measured; the range from low to high includes it.
By their numbers in this assay, from the lowest: compounds 2 and 3 (each within the scatter of the next); then compound 1.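

In this assay, methyl and chloro cannot be told apart at this spot on the six-membered ring, para to a large group: the step is small, a 1.4-fold higher number from compound 2 to compound 3 (0.15 log units; within the scatter), and no ranking of the two follows from it. The methyl group of compound 1 and compound 3 tells a different story, since 3-methylphenyl and 4-methylphenyl differ by more than the scatter, with a 2.9-fold lower number from compound 1 to compound 3 (0.47 log units; beyond the scatter), so among these three compounds the place of the group matters more than whether it is methyl or chloro. No measurement here gives a reason for either step.

On these data alone, whether this result holds for other groups at the same spot stays open, for instance an amine, a carboxylic acid or a longer chain, any of which would test how much this position accepts beyond methyl and chloro. A chloro group on the carbon that holds the methyl in compound 1 would also be needed to show whether chloro and methyl stay matched at that other place on the ring.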